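A few compounds are considered here, and "the series" means these few. Any claim that something is new, unique, unknown or untested is made for them only; others in the source may bear on it.

Going by the values given here, in an assay on U2OS cells for inhibition of secreted frizzled-related protein 1 (Homo sapiens), read by a luciferase reporter, with a stated time of 18 h (a higher number here means that more compound is needed for the effect, a lower number that less compound is needed), compound 1 `CN(C)c1ccc(C(=O)N2CCC(NS(=O)(=O)c3cc(S(=O)(=O)c4ccccc4)ccc3C(F)(F)F)CC2)cn1` gives 70 nM, the lower of the two numbers measured so far. Compound 2 `CC(C)(C)OC(=O)N1CCC(CC(=O)N2CCC(NS(=O)(=O)c3cc(S(=O)(=O)c4ccccc4)ccc3C(F)(F)F)CC2)CC1` gives 400 nM, and the gap between these two values lies beyond the usual scatter. Compound 3 `O=C(C1CCNCC1)N1CCC(NS(=O)(=O)c2cc(S(=O)(=O)c3ccccc3)ccc2C(F)(F)F)CC1` has not yet been measured. It differs from compound 1 in a single place: piperidin-4-yl in place of 6-(dimethylamino)pyridin-3-yl on a carbonyl carbon. Among the compounds with values here, no measured pair shows this particular change, so the size of the step is uncertain; the estimated step in this assay is a 3.6-fold higher number from compound 1 to compound 3 (0.55 log units; beyond the scatter), an upward move meaning more compound would be needed. Compound 3 is thus expected to give about 250 nM, within a range from 80 nM to 800 nM.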

Compound 3, half-maximal effective concentration: 150 nM
Compound 3: middle estimate off by 1.7-fold (0.22 log units), on the high side, within the range that was stated.
By their numbers in this assay, from the lowest: compound 1; then compound 3; then compound 2.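

The place on the carbonyl carbon accepts a non-aromatic ring: putting piperidin-4-yl in place of 6-(dimethylamino)pyridin-3-yl gives, in this assay, a 2.1-fold higher number from compound 1 to compound 3 (0.33 log units; beyond the scatter), a modest step. An aromatic ring is therefore not required for activity here, although compound 1 keeps the lower number. No measured evidence explains this step. Still open, on these data alone, is whether the lower number of compound 1 goes with its pyridine ring or with its dimethylamino group. A plain pyridin-3-yl or a 1-methylpiperidin-4-yl group at this place would help separate these parts.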